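Bromo to Iodo on the Ester Aryl: Compound 3

The source may report more compounds than this note shows. Statements on the series, on what has been measured and on what is new or still open speak of the compounds shown alone.

Compound 2 `O=C(OC1(C(=O)Nc2ccc([N+](=O)[O-])cc2)CCCCC1)c1ccc(Br)cc1` was tested in an ADME assay on WI-38 cells (Homo sapiens) for inhibition, read by MTT assay, with a stated time of 72 h (on this read-out higher numbers stand for weaker inhibition and lower numbers for stronger inhibition), and gives 523 nM, the higher of the two numbers recorded so far. For the measured compounds named here, its nearest neighbour, compound 1 `O=C(OC1(C(=O)Nc2ccc([N+](=O)[O-])cc2)CCCCC1)c1ccc(C(F)(F)F)cc1`, gives 185 nM; the only measured step, a 2.8-fold higher number from compound 1 to compound 2 (0.45 log units; beyond the scatter), replaces trifluoromethyl with bromo on the aromatic ring of the ester. Compound 3 `O=C(OC1(C(=O)Nc2ccc([N+](=O)[O-])cc2)CCCCC1)c1ccccc1I` has not yet been measured. It differs from compound 2 by 2-iodophenyl in place of 4-bromophenyl on a carbonyl carbon. Going by the values given here, no measured step covers this kind of change: the single known step ends at 4-bromophenyl and so speaks only to the starting point, not to the move to 2-iodophenyl. With nothing to guide direction, the step expected in this assay is a 1.1-fold higher number from compound 2 to compound 3 (0.06 log units; within the scatter), with the sign uncertain and the range kept wide. Compound 3 is therefore estimated at 600 nM, with a range from 200 nM to 2000 nM.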

Compound 3, half-maximal inhibitory concentration: 396 nM
Compound 3: the middle estimate sits 1.5-fold (0.18 log units) above what was measured; measured number inside the range.
By their numbers in this assay, from the lowest: compound 1; then compounds 3 and 2 (each within the scatter of the next).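

In this assay, the change from 4-bromophenyl to 2-iodophenyl on this carbonyl carbon gives a 1.3-fold lower number from compound 2 to compound 3 (0.12 log units; within the scatter), so this position tolerates a change of both halogen and ring placement without a step beyond the scatter. Compound 1 remains apart from this pair, with a 2.1-fold higher number from compound 1 to compound 3 (0.33 log units; beyond the scatter) adding to a 2.8-fold higher number from compound 1 to compound 2 (0.45 log units; beyond the scatter), so 4-(trifluoromethyl)phenyl gives the lowest number of the three groups. No available evidence accounts for these results.

The compounds shown leave open whether the change of halogen and the change of ring placement each have little effect or instead offset each other, a question that 4-iodophenyl or 2-bromophenyl would address. They also leave open how this position would respond to an amine or a carboxylic acid on the aromatic ring.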